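The compounds below may be only part of what the source reports. "The series", "measured", "known", "first", "only" and "open" are said of these compounds alone.

Compound 1, `Cc1nc(Nc2ccc(Cl)c(Cl)c2)sc1C(=O)/C=C/c1ccccc1`: 10600 nM
Compound 2, `COc1cc(/C=C/C(=O)c2sc(Nc3cccc(Cl)c3)nc2C)cc(OC)c1OC`: 11600 nM
Compound 3, `Cc1nc(Nc2ccc(Cl)c(Cl)c2)sc1C(=O)/C=C/c1ccc(Cl)cc1`: 22700 nM

These three compounds were tested in a functional assay on BGC-823 cells (Homo sapiens) for cytotoxicity, read by MTT assay; on this read-out higher numbers stand for weaker inhibition and lower numbers for stronger inhibition. Compound 1 gives 10600 nM and compound 3 gives 22700 nM. Compound 3 differs from compound 1 by chloro in place of hydrogen on an aromatic carbon, and this change made a 2.1-fold higher number from compound 1 to compound 3 (0.33 log units; beyond the scatter). Compound 2 gives 11600 nM; its value and that of compound 1 lie within the usual scatter of each other, so no difference between them can be claimed. How the core of compound 2 differs from the core of compound 1 is not broken down here.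

Compound 4, `COc1cc(/C=C/C(=O)c2sc(Nc3ccc(Cl)c(Cl)c3)nc2C)cc(OC)c1OC`, has not yet been measured. It differs from compound 2 by chloro in place of hydrogen on an aromatic carbon. For the measured compounds named here, this is the same kind of change as the one from compound 1 to compound 3, but not the same: in compound 4 the entering chloro sits ortho to a chloro group, and this is not so in compound 3. Compound 4 is expected to show a 1.4-fold higher number from compound 2 to compound 4 (0.14 log units; within the scatter), beside the measured 2.1-fold higher number from compound 1 to compound 3 (0.33 log units; beyond the scatter). Going by the values given here, this expectation rests on the measured step of a 2.1-fold higher number from compound 1 to compound 3 (0.33 log units; beyond the scatter), the only example of this kind of change among the measured compounds, with wider uncertainty since the surroundings of the change are not identical. Compound 4 is therefore estimated at 16000 nM, with a range from 6000 nM to 45000 nM.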

Compound 4, half-maximal inhibitory concentration: > 25000 nM
Compound 4: only a limit was reported; the forecaster's own chance of this, stated with the estimate: 5%; middle value at least 1.5-fold (0.19 log units) away from the limit.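

In this assay compound 4 gives > 25000 nM, which is a limit of the assay and not an exact number. Putting chloro in place of hydrogen on the (3-chlorophenyl)amino group gives an at least 2.1-fold higher number from compound 2 to compound 4 (0.33 log units; beyond the scatter), so on this second core the change again points towards weaker inhibition, and the direction seen with the earlier pair carries over: the same change on two cores in this assay, a 2.1-fold higher number (0.33 log units; beyond the scatter) from compound 1 to compound 3 and an at least 2.1-fold higher number (0.33 log units; beyond the scatter) from compound 2 to compound 4; the limit leaves it open whether they differ. For the compounds shown here, this does not show that the size of the effect carries over, nor does it make a general rule, since there are only two pairs, the exact value of compound 4 is unknown, and the entering chloro sits ortho to a chloro group in compound 4 but not in compound 3.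

The compounds shown leave open how far the number for compound 4 lies past the limit, and so whether the change costs more on one core than on the other. They also leave open whether the same direction would hold for groups other than chloro at this place, such as fluoro, a hydroxyl group or an amine, or whether it is particular to chloro.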